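Replacing 4-pentylphenyl with butyl in compound 2

The source may hold more compounds than are shown below. What is called first, only, known or untested is meant among the compounds shown, and "the series" means these compounds.

Among the compounds with values here, in a functional assay on CCRF-CEM cells (Homo sapiens) for antiproliferative activity, read by MTT assay, with a stated time of 3 days (a lower number here means a stronger inhibitor, a higher number a weaker inhibitor), compound 2 (`CCCCCc1ccc(C#Cc2cn(C/C=C/CN3C(=O)c4ccccc4C3=O)c(=O)[nH]c2=O)cc1`) gives 23000 nM and stands lowest of the two numbers so far, while its double-bond isomer, compound 1 (`CCCCCc1ccc(C#Cc2cn(C/C=C\CN3C(=O)c4ccccc4C3=O)c(=O)[nH]c2=O)cc1`), gives 102000 nM as its reading. Compound 3 (`CCCCC#Cc1cn(C/C=C/CN2C(=O)c3ccccc3C2=O)c(=O)[nH]c1=O`) carries butyl in place of 4-pentylphenyl on a triple-bonded carbon. Within the data shown here, the only measured step (a 4.4-fold lower number from compound 1 to compound 2 (0.65 log units; beyond the scatter)) rests on the fact that compounds 1 and 2 differ only in the configuration as drawn and so offers little guide to this swap. A modest move toward a higher number, meaning weaker inhibition, is expected (a 2.2-fold higher number from compound 2 to compound 3 (0.34 log units; beyond the scatter)). The estimated value for compound 3 is 50000 nM (15000 nM to 150000 nM).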

Compound 3, half-maximal inhibitory concentration: 192000 nM
Beside the measured number, compound 3's estimate is 3.8-fold (0.58 log units) below it, and the stated range ends below it.
By their numbers in this assay, from the lowest: compound 2; then compounds 1 and 3 (each within the scatter of the next).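

Putting butyl in place of 4-pentylphenyl on a triple-bonded carbon gives an 8.3-fold higher number from compound 2 to compound 3 (0.92 log units; beyond the scatter) and so weaker inhibition. Within the data shown here, this is the first sign that the group at this position matters, and not only the drawn shape of the double bond, although it rests on one pair of compounds. Nothing at hand explains the size of this step.

The change removes the aromatic ring and shortens the carbon group together, leaving their shares unseparated. A plain phenyl group or a longer chain such as octyl at this place could tell them apart.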